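Cytotoxicity notes: benzyl ether variation on the shared core

The source may report more compounds than this note shows. Statements on the series, on what has been measured and on what is new or still open speak of the compounds shown alone.

Compound 1 `CN(c1ccc(NC(=O)c2cc(C(F)(F)F)cc(C(F)(F)F)c2)cc1OCc1cccc(C(F)(F)F)c1)S(C)(=O)=O` and compound 2 `CN(c1ccc(NC(=O)c2cc(C(F)(F)F)cc(C(F)(F)F)c2)cc1OCc1ccccc1C(F)(F)F)S(C)(=O)=O` share one core and differ only in the benzyl ether. In an ADME assay on HEK293 cells (Homo sapiens) for cytotoxicity, read by MTT assay, with a stated time of 48 h (on this read-out higher numbers stand for weaker inhibition and lower numbers for stronger inhibition), compound 1 gives > 500000 nM, which is a limit of the assay. In this assay compound 2 gives > 500000 nM, likewise a limit. The step that the two limits leave unreadable from compound 1 to compound 2 therefore cannot be read, since both ends sit at the limit of > 500000 nM in this assay, at which 2 of the 2 values shown sit. Compound 2 thus stands at the limit, with no number of its own on the read-out.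

Compound 3 `Cc1ccc(C(F)(F)F)cc1COc1cc(NC(=O)c2cc(C(F)(F)F)cc(C(F)(F)F)c2)ccc1N(C)S(C)(=O)=O` carries 2-methyl-5-(trifluoromethyl)phenyl in place of 2-(trifluoromethyl)phenyl on a saturated chain carbon bound to an oxygen on an aromatic ring. For the measured compounds named here, the only step measured in the set, a step that the two limits leave unreadable from compound 1 to compound 2, bears on this change as a variation of the same benzyl ether, and it was unreadable. Going by the values given here, no step in the set gives a direction or a size beyond the scatter for the move to compound 3. The expected step of a number no higher from compound 2 to compound 3 (the limit leaves the size open) is therefore none beyond the scatter, most probably ending in a limit once more. The estimate for compound 3 in this assay is 500000 nM, within 200000 nM to 2000000 nM.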

Compound 3, half-maximal inhibitory concentration: > 500000 nM
Compound 3: no number, only a limit; the forecaster's own chance of this, stated with the estimate: 85%; the middle value sits exactly at the limit.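

In this assay compound 3 gives > 500000 nM, which is a limit of the assay. For the compounds shown here, no step among compound 1, compound 2 and compound 3 can be read: the limit of > 500000 nM in this assay, at which 3 of the 3 values shown sit. The compounds shown leave open whether these benzyl ethers differ at all in cytotoxicity, and none of the three has a number of its own.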